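The source may hold more compounds than are shown below. What is called first, only, known or untested is meant among the compounds shown, and "the series" means these compounds.

Measured so far:
- compound 1, `CCCCCC(=O)c1ccc(OCCCN2CCNCC2)cc1`: 14500 nM
- compound 2, `CCCCCC(=O)c1ccc(OCCCN2CCN(S(=O)(=O)c3ccc(C#N)cc3)CC2)cc1`: 12300 nM
- compound 3, `CCCCCC(=O)c1ccc(OCCCN2CCN(C(=O)c3c[nH]cn3)CC2)cc1`: 19500 nM

All three compounds share one core and differ only in what sits on the amine nitrogen of the six-membered ring. In an assay on isolated protein for binding affinity to histamine H2 receptor (Homo sapiens) (on this read-out higher numbers stand for weaker inhibition and lower numbers for stronger inhibition), compound 1 gives 14500 nM, which places it second highest among the three numbers, with compound 2 nearest and compound 3 furthest, both within the scatter. The two measured steps from compound 1 are small: a 1.2-fold lower number from compound 1 to compound 2 (0.07 log units; within the scatter) and a 1.3-fold higher number from compound 1 to compound 3 (0.13 log units; within the scatter). The comparison between the two substituted compounds is also small, a 1.6-fold higher number from compound 2 to compound 3 (0.20 log units; within the scatter).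

Compound 4, `CCCCCC(=O)c1ccc(OCCCN2CCN(CC3CC3)CC2)cc1`, has not yet been measured. It differs from compound 1 by cyclopropylmethyl in place of hydrogen on an amine nitrogen in a ring. Both steps that bear on this change, a large sulfonyl group and a small carbonyl group entering at the same nitrogen, stayed within the scatter, so no step beyond the scatter is expected in this assay for compound 4 either. Compound 4 is therefore estimated to give about 12000 nM in this assay, with a range from 4000 nM to 40000 nM, which would mean an expected step of a 1.2-fold lower number from compound 1 to compound 4 (0.08 log units; within the scatter).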

Compound 4, inhibition constant: 18600 nM
Beside the measured number, compound 4's estimate is 1.6-fold (0.19 log units) below it; low and high end bracket the measured number.
By their numbers in this assay, from the lowest: compounds 2, 1, 4 and 3 (each within the scatter of the next).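

In this assay, cyclopropylmethyl, a group of carbon only, now joins the sulfonyl and carbonyl groups at this amine nitrogen, and it too stays within the scatter of the unsubstituted compound: a 1.3-fold higher number from compound 1 to compound 4 (0.11 log units; within the scatter). It also cannot be told apart from either earlier substituted compound, with a 1.0-fold lower number from compound 3 to compound 4 (0.02 log units; within the scatter) and a 1.5-fold higher number from compound 2 to compound 4 (0.18 log units; within the scatter), so all four compounds read alike whichever of these groups sits on this nitrogen. No measured evidence is available to explain why these changes leave the number within the scatter.

The compounds shown leave open whether a longer carbon chain or a chain ending in a carboxylic acid on this nitrogen would move the number beyond the scatter. They also leave open whether a change elsewhere on the shared core would do so.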